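Replacing the amide substituent of compound 3

The source may hold more compounds than are shown below. What is called first, only, known or untested is meant among the compounds shown, and "the series" means these compounds.

Of the compounds shown here, three have been read in a functional assay on HCT-116 cells (Homo sapiens) for antiproliferative activity, read by MTT assay, with a stated time of 72 h; on this read-out higher numbers stand for weaker inhibition and lower numbers for stronger inhibition. Compound 3 `Cc1noc(C)c1-c1nn(Cc2ccc(C(=O)NC3CC(C)(C)N([O])C(C)(C)C3)cc2)c(=O)c2ccccc12` gives 36800 nM. Compound 1 `CN1CCC(NC(=O)c2ccc(Cn3nc(-c4cnn(C)c4)c4ccccc4c3=O)cc2)CC1` gives 69500 nM, and these two values lie within the scatter of each other. Compound 2 `Cc1noc(C)c1-c1nn(Cc2ccc(C(=O)N3CCCCC3)cc2)c(=O)c2ccccc12` is reported only as a limit, > 100000 nM.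

Compound 4 `Cc1noc(C)c1-c1nn(Cc2ccc(C(=O)NC3CCN(C)CC3)cc2)c(=O)c2ccccc12` has not yet been measured. Its difference from compound 3 is a group of 7 heavy atoms (6 carbon, 1 nitrogen; one six-membered non-aromatic ring with 1 hetero atom) in place of a group of 11 heavy atoms (9 carbon, 1 nitrogen, 1 oxygen; one six-membered non-aromatic ring with 1 hetero atom), on an amide-type nitrogen. Among the measured compounds shown here, the one measured step that bears on this change is an at least 2.7-fold lower number from compound 2 to compound 3 (0.43 log units; beyond the scatter), which alters the group on the same carbonyl carbon and starts from a limit. Compound 1 also carries the 1-methylpiperidin-4-yl group on the amide-type nitrogen but differs elsewhere, and its value is 69500 nM.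

On this thin evidence, no step beyond the scatter is expected in this assay, and the estimated step is a 1.6-fold higher number from compound 3 to compound 4 (0.21 log units; within the scatter). Compound 4 is estimated at 60000 nM, with an expected range of 25000 nM to 100000 nM.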

Compound 4, half-maximal inhibitory concentration: 84900 nM
Beside the measured number, compound 4's estimate is 1.4-fold (0.15 log units) below it, within the range that was stated.
By their numbers in this assay, from the lowest: compounds 3, 1 and 4 (each within the scatter of the next, the first and the last beyond it). At a limit, above all of these: compound 2.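

In this assay, 1-methylpiperidin-4-yl on the amide-type nitrogen in place of the larger group of compound 3 gives a 2.3-fold higher number from compound 3 to compound 4 (0.36 log units; beyond the scatter), the first measured sign that the group at this position alters the read-out with the rest of the structure held fixed. With that amide group kept, 3,5-dimethyl-1,2-oxazol-4-yl in place of 1-methyl-1H-pyrazol-4-yl on an aromatic carbon gives a 1.2-fold higher number from compound 1 to compound 4 (0.09 log units; within the scatter), a step that lies within the scatter. (1-Methylpiperidin-4-yl)amino in place of piperidin-1-yl on a carbonyl carbon gives an at least 1.1-fold lower number from compound 2 to compound 4 (0.07 log units; that floor lies within the scatter), and this step starts from a limit, so its size cannot be read. Compound 2 is reported only as a limit: the limit of > 100000 nM in this assay, at which 1 of the 4 values shown sits.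

The step from compound 3 to compound 4 changes the methyl groups and the oxygen of the leaving group together, so it cannot say which of them matters. Open also is how a plain cyclohexyl or a piperidin-4-yl without the methyl group would read on the same amide-type nitrogen.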